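Shortening a butylamino chain at a cytotoxicity limit

The compounds below may be only part of what the source reports. "The series", "measured", "known", "first", "only" and "open" are said of these compounds alone.

Three measured compounds and one unmeasured compound share the core seen in compound 2 `CCCCNc1nc(N)nc2c1ncn2/C=C1/CC1(CO)CO`, which carries a butylamino group on an aromatic carbon. For compound 1 `CC(C)CSc1nc(N)nc2c1ncn2/C=C1/CC1(CO)CO` the result in an ADME assay on MOLT-3 cells (Homo sapiens) for cytotoxicity, with a stated time of 7 days (on this read-out higher numbers stand for lower toxicity in this test and lower numbers for higher toxicity in this test), is "not determined" (no result reported). In this assay compound 2 gives > 20000 nM, which is a limit of the assay rather than a number. Compound 3 `Nc1nc(SC2CCCC2)c2ncn(/C=C3/CC3(CO)CO)c2n1` gives > 20000 nM in this assay, again a limit and not a number. Exchanging butylamino for cyclopentylsulfanyl on an aromatic carbon therefore yields a step that the two limits leave unreadable from compound 2 to compound 3, and nothing about its size can be read.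

Compound 4 `CNc1nc(N)nc2c1ncn2/C=C1/CC1(CO)CO` differs from compound 2 by hydrogen in place of propyl on a saturated chain carbon bound to a nitrogen on an aromatic ring. For the measured compounds named here, no measured step touches this chain, so no measured step shows whether shortening it moves this assay in either direction. Because (the limit of > 20000 nM in this assay, at which 2 of the 3 values shown sit), the expectation for compound 4 is that it also remains at that limit. Compound 4 is estimated at 20000 nM, within 10000 nM to 40000 nM. The step expected from compound 2 to compound 4 is a number no higher from compound 2 to compound 4 (the limit leaves the size open), which amounts to none beyond the usual scatter.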

Compound 4, half-maximal cytotoxic concentration: > 20000 nM
Compound 4: a limit, no number (the forecaster's own chance of this, stated with the estimate: 80%); the middle value lies on the limit itself.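

Compound 2, compound 3 and compound 4 each give a limit rather than a number in this assay, so the steps among them cannot be read. The compounds shown leave open whether exchanging butylamino, methylamino or cyclopentylsulfanyl changes the cytotoxicity read-out at all, and what number each compound would give.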